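This account rests on a few compounds, and the source may have more. Where it says the series, first, only, none or still open, it means among the compounds named here.

In a functional assay on HeLa S3 cells (Homo sapiens) for cytotoxicity, read by WST assay (a lower number here means a stronger inhibitor, a higher number a weaker inhibitor), compound 2 `CC(C)CC(=O)O[C@@H]1OC=C(CO[C@@H]2O[C@H](CO)[C@@H](O)[C@H](O)[C@H]2O)[C@H]2C[C@H](OC(=O)/C=C/c3ccc(O)cc3)[C@](O)(CO)[C@@H]12` gives 3390 nM. Compound 1 `CC(C)CC(=O)O[C@@H]1OC=C(CO)[C@H]2C[C@H](OC(=O)/C=C\c3ccc(O)cc3)[C@](O)(CO)[C@@H]12` gives 3110 nM and compound 3 `CC(C)CC(=O)O[C@@H]1OC=C(CO)[C@H]2C[C@H](OC(=O)/C=C/c3ccc(O)cc3)[C@](O)(CO)[C@@H]12` gives 2890 nM in the same test, so compound 2 carries the highest of the three numbers shown, yet all three sit within the scatter of one another. Compound 4 `CC(C)CC(=O)O[C@@H]1OC=C(CO[C@@H]2O[C@H](CO)[C@@H](O)[C@H](O)[C@H]2O)[C@H]2C[C@H](OC(=O)/C=C\c3ccc(O)cc3)[C@](O)(CO)[C@@H]12` differs from compound 2 in a single respect: the two compounds have the same atoms and bonds and differ only in configuration as drawn: 1 of 11 stereo elements differ; a double bond is drawn E in compound 2 and Z in compound 4. Among the compounds with values here, the step that bears on this is the one between the two compounds lacking the 3,4,5-trihydroxy-6-(hydroxymethyl)oxan-2-yl group, where the same change of drawn double-bond form gave a 1.1-fold lower number from compound 1 to compound 3 (0.03 log units; within the scatter). Taking that group away itself gave only a 1.2-fold lower number from compound 2 to compound 3 (0.07 log units; within the scatter). A step within the scatter is therefore expected here, a 1.0-fold higher number from compound 2 to compound 4 (0.01 log units; within the scatter). Compound 4 is estimated at 3500 nM, between 1800 nM and 7000 nM.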

Compound 4, half-maximal inhibitory concentration: 4670 nM
Compound 4: the middle estimate sits 1.3-fold (0.13 log units) below what was measured, within the range that was stated.
By their numbers in this assay, from the lowest: compounds 3, 1, 2 and 4 (each within the scatter of the next).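

In this assay, with the 3,4,5-trihydroxy-6-(hydroxymethyl)oxan-2-yl group in place, changing the double bond from E to Z gives a 1.4-fold higher number from compound 2 to compound 4 (0.14 log units; within the scatter), so this change now stays within the scatter with and without that group. Adding the group to the Z form gives a 1.5-fold higher number from compound 1 to compound 4 (0.18 log units; within the scatter), so the group also makes no step beyond the scatter in either double-bond form. Its effect reads the same in both forms: the same change on two cores in this assay, a 1.2-fold lower number (0.07 log units; within the scatter) from compound 2 to compound 3 and a 1.5-fold lower number (0.18 log units; within the scatter) from compound 4 to compound 1, 1.3-fold (0.11 log units) apart, within the scatter of two such steps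

All four compounds keep the same ester groups. As far as these compounds go, whether an amide or a longer chain in their place would move the number beyond the scatter stays open.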